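The compounds below may be only part of what the source reports. "The series", "measured", "known", "first", "only" and "open" are said of these compounds alone.

Compound 1 `C=C1C(=O)O[C@H]2CC3=C[C@H](C/C(C)=C/[C@@H](OC(=O)c4ccc(C(F)(F)F)cc4)[C@H]12)OC3=O` is one of three esters built on a shared core, each differing only in the group attached to the carbonyl carbon of the ester. In a functional assay on A549 cells (Homo sapiens) for cytotoxicity, read by MTT assay, with a stated time of 48 h (a lower number here means a stronger inhibitor, a higher number a weaker inhibitor), compound 1 gives > 10000 nM, which is a limit of the assay rather than a number. Compound 2 `C=C1C(=O)O[C@H]2CC3=C[C@H](C/C(C)=C/[C@@H](OC(=O)/C=C/c4ccccc4)[C@H]12)OC3=O` carries 2-phenylethenyl in that position and gives 4800 nM in this assay, and the step of an at least 2.0-fold lower number from compound 1 to compound 2 (0.31 log units; beyond the scatter) is the only one here that is read as a true difference. Compound 3 `C=C1C(=O)O[C@H]2CC3=C[C@H](C/C(C)=C/[C@@H](OC(=O)CCCCC)[C@H]12)OC3=O` carries pentyl in that position. In this assay compound 3 gives > 10000 nM, again a limit. Because of the limit of > 10000 nM in this assay, at which 2 of the 3 values shown sit, the step that the two limits leave unreadable from compound 1 to compound 3 cannot be sized, while the step of an at least 2.0-fold higher number from compound 2 to compound 3 (0.31 log units; beyond the scatter) can.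

The compound still to be measured is compound 4 `C=C1C(=O)O[C@H]2CC3=C[C@H](C/C(C)=C/[C@@H](OC(=O)CC4CCCCC4)[C@H]12)OC3=O`, which differs from compound 1 as follows: cyclohexylmethyl in place of 4-(trifluoromethyl)phenyl on a carbonyl carbon. The entering cyclohexylmethyl resembles the pentyl of compound 3 more than either aromatic group, and compound 3 sits at the limit with > 10000 nM. Compound 4 is therefore expected to give about 15000 nM in this assay, somewhere between 5000 nM and 50000 nM. The expected step is a step that the limit leaves unreadable from compound 1 to compound 4, most likely ending at a limit again.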

Compound 4, half-maximal inhibitory concentration: 6900 nM
Estimate against measurement, compound 4: 2.2-fold (0.34 log units) above, and the stated range covers the measured number.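

Compound 4 shows that an aromatic ring on this carbonyl carbon is not needed for a readable number in this assay, since its non-aromatic cyclohexylmethyl group gives one where the pentyl of compound 3 reaches only a limit. Within the data shown here, the one step here between two readable numbers is a 1.4-fold higher number from compound 2 to compound 4 (0.16 log units; within the scatter), so cyclohexylmethyl and 2-phenylethenyl cannot be told apart at this position. The other two steps are an at least 1.4-fold lower number from compound 1 to compound 4 (0.16 log units; that floor lies within the scatter) and an at least 1.4-fold lower number from compound 3 to compound 4 (0.16 log units; that floor lies within the scatter), and the second of these amounts to cyclohexyl in place of butyl on a saturated chain carbon bound to a carbonyl carbon, yet neither floor alone establishes a true difference.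

How large those two steps really are stays open because each starts from a limit: the limit of > 10000 nM in this assay, at which 2 of the 4 values shown sit.

Also open, on these data alone, is how this position would respond to a group carrying an amine or a carboxylic acid, or to a longer chain, and whether any such group would give a number clearly different from those of compound 2 and compound 4.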